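The source may report more compounds than this note shows. Statements on the series, on what has been measured and on what is new or still open speak of the compounds shown alone.

Measured so far:
compound 1 `O=C(C1CCN(c2ccncn2)CC1)N1N=CC[C@H]1c1ccccc1`: 3.3 h
compound 2 `N#Cc1cc(N2CCC(C(=O)N3N=CC[C@H]3c3cc(F)cc(F)c3)CC2)ncn1`: 3.3 h

In an ADME assay on cells (Hepatocyte, Homo sapiens) for metabolic stability (a lower number here means that the compound disappears faster, a higher number that the compound lasts longer), compound 1 gives 3.3 h. Compound 2, `N#Cc1cc(N2CCC(C(=O)N3N=CC[C@H]3c3cc(F)cc(F)c3)CC2)ncn1`, gives 3.3 h in the same assay, and the two values are within the usual scatter of each other, so compound 1 stands level with compound 2 at the digits shown. Going by the values given here, no pair of measured compounds that differ in a single place is available here, so no measured step gives a scale for what a single change does in this assay.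

Compound 3, `CC(=O)N1CCC(C(=O)N2N=CC[C@H]2c2ccccc2)CC1`, has not been measured. Relative to compound 1 the difference is acetyl in place of pyrimidin-4-yl on an amine nitrogen in a ring. Among the compounds with values here, with no measured single-point step to lean on, the expectation is of a small shift, if any, in this assay, at most of the order of the scatter and more likely toward a shorter half-life than a longer one. Compound 3 is therefore expected to give about 2.5 h, within a range from 1 h to 6 h, which means an expected step of a 1.3-fold lower number from compound 1 to compound 3 (0.12 log units; within the scatter).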

Compound 3, half-life: > 3.11 h
Compound 3 was reported as a limit; the forecaster's own chance of this, stated with the estimate: 10%; at least 1.2-fold (0.09 log units) between middle value and limit.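

In this assay compound 3 gives > 3.11 h, which is a limit and not a number. The step from compound 1 to compound 3 therefore cannot be read. The compounds shown leave open whether acetyl in place of pyrimidin-4-yl on an amine nitrogen in a ring changes the half-life, and in which direction.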